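This account rests on a few compounds, and the source may have more. Where it says the series, first, only, none or still open, it means among the compounds named here.

In a functional assay on B16-F0 cells (Mus musculus) for inhibition, read by CCK-8 assay, with a stated time of 48 h (on this read-out higher numbers stand for weaker inhibition and lower numbers for stronger inhibition), the measured compounds read as follows
- compound 1 `COc1cc(-c2ccnc3cc(-c4c[nH]c5ccccc45)nn23)cc(OC)c1OC` gives 40 nM
- compound 2 `COc1cc(-c2ccnc3cc(-c4ccc(Cl)cc4)nn23)cc(OC)c1OC` gives 4090 nM
- compound 3 `COc1cc(-c2ccnc3cc(-c4ccc(C)c(C)c4)nn23)cc(OC)c1OC` gives 391 nM

Compound 3 stands second highest of the three, above compound 1 and below compound 2. Compound 4 `COc1cc(-c2ccnc3cc(-c4ccccc4)nn23)cc(OC)c1OC` carries phenyl in place of 3,4-dimethylphenyl on an aromatic carbon and is otherwise unchanged. For the measured compounds named here, two measured steps bear on this, a 10-fold lower number from compound 2 to compound 3 (1.02 log units; beyond the scatter) and a 9.8-fold higher number from compound 1 to compound 3 (0.99 log units; beyond the scatter) (one large, one modest). Neither isolates the loss of the two methyl groups, so the expectation is loose. A modest step towards a higher number is expected in this assay for this change. Compound 4 is estimated at 900 nM (expected range 250 nM to 3500 nM). The expected step is a 2.3-fold higher number from compound 3 to compound 4 (0.36 log units; beyond the scatter) and remains an estimate.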

Compound 4, half-maximal inhibitory concentration: 4730 nM
Compound 4: the middle estimate sits 5.3-fold (0.72 log units) below what was measured, outside the stated range (above it).
By their numbers in this assay, from the lowest: compound 1; then compound 3; then compounds 2 and 4 (each within the scatter of the next).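

In this assay the loss of the two methyl groups gives a 12-fold higher number from compound 3 to compound 4 (1.08 log units; beyond the scatter) and so shows that the 3,4-dimethylphenyl group matters at this position. Hydrogen in place of chloro gives a 1.2-fold higher number from compound 2 to compound 4 (0.06 log units; within the scatter) and separates neither compound from the other, while a 120-fold higher number from compound 1 to compound 4 (2.07 log units; beyond the scatter) sets 1H-indol-3-yl well apart from plain phenyl. Nothing given here accounts for these differences. Open, from the compounds shown here alone, is whether a single methyl would suffice, and whether a methoxy group or an amine on the phenyl would bring the number closer to that of compound 1.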